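The compounds below may be only part of what the source reports. "The series", "measured", "known", "first", "only" and "open" are said of these compounds alone.

Measured compounds in a functional assay on the whole organism (Tail, strain ICR) with Mus musculus as the target, in the tail flick test, with a stated time of 90 min, at a dose of 25 umol/kg by the oral route; on this read-out higher numbers stand for a stronger effect at the one dose given and lower numbers for a weaker effect:
- compound 1 `NC(=O)CC[C@H](NC(=O)CN(c1ncnc2c1ncn2C1CCCCO1)C1CC1)C(=O)OCc1ccccc1`: 37.8%
- compound 2 `CC[C@H](C)[C@H](NC(=O)CN(c1ncnc2c1ncn2C1CCCCO1)C1CC1)C(=O)OCc1ccccc1`: 22.6%
- compound 3 `O=C(CN(c1ncnc2c1ncn2C1CCCCO1)C1CC1)N[C@@H](CO)C(=O)OCc1ccccc1`: 32.2%

Compound 3 sits as the middle of the three numbers, but both neighbours lie within the scatter: a number 5.6 percentage points lower from compound 1 to compound 3 (within the scatter) and a number 9.6 percentage points higher from compound 2 to compound 3 (within the scatter). Going by the values given here, the only step beyond the scatter in the set is a number 15.2 percentage points lower from compound 1 to compound 2 (beyond the scatter), a change on the carbon bound to the amide-type nitrogen and the carbonyl carbon, not at the position now in question.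

Compound 4 `O=C(CN(c1ncnc2c1ncn2C1CCCCO1)C1CC1)N[C@@H](CC(=O)OCc1ccccc1)C(=O)OCc1ccccc1` differs from compound 3 as follows: benzyloxycarbonyl in place of hydroxy on a saturated chain carbon, two bonds along the chain from an amide-type nitrogen and a carbonyl carbon. The step that bears most directly on this is the one at the same place, which was within the scatter; the other two steps concern the adjacent carbon and give one modest drop and one shift within the scatter. Among the compounds with values here, no measured step introduces a benzyloxycarbonyl group, so its effect here is unknown; the expectation is a step of no more than the scatter, a number 2.2 percentage points lower from compound 3 to compound 4 (within the scatter). Compound 4 is therefore estimated at 30%, with a range from 15% to 45% in this assay.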

Compound 4, a percentage reported as activity, at one dose (the size of the read-out at that dose, not a potency): 25.1%
For compound 4 the middle estimate is 4.9 percentage points above the measured one, within the range that was stated.
By their numbers in this assay, from the lowest: compounds 2, 4, 3 and 1 (each within the scatter of the next, the first and the last beyond it).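

In this assay, benzyloxycarbonyl in place of hydroxy, on a saturated chain carbon two bonds along the chain from an amide-type nitrogen and a carbonyl carbon, gives a number 7.1 percentage points lower from compound 3 to compound 4 (within the scatter), so this place takes a group of 10 heavy atoms with a six-membered aromatic ring without a step beyond the scatter. Replacing carbamoylmethyl at the same place now gives a number 12.7 percentage points lower from compound 1 to compound 4 (beyond the scatter), a step beyond the scatter that hydroxy did not give, while a number 2.5 percentage points higher from compound 2 to compound 4 (within the scatter) leaves (benzyloxycarbonyl)methyl and sec-butyl unseparated. Nothing available accounts for these steps.

Still open, going by these compounds, is whether a carboxylic acid or an amine at this place would move the read-out beyond the scatter from compound 3. A longer chain carrying the carbamoyl group is equally untested among the compounds shown.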